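Ketone selenoester series: from tert-butyl to methyl

The source may hold more compounds than are shown below. What is called first, only, known or untested is meant among the compounds shown, and "the series" means these compounds.

- compound 1 `O=C1[Se]C(=O)c2ccccc21`: > 100000 nM
- compound 2 `CC(C)(C)C(=O)C[Se]C(=O)c1ccc(Cl)cc1`: 1630 nM

Both compounds were tested in a functional assay on COLO 205 cells (Homo sapiens) for cytotoxicity, read by MTT assay, with a stated time of 24 h; a lower number here means a stronger inhibitor, a higher number a weaker inhibitor. Compound 1 reads > 100000 nM, which is a limit of the assay and not a number. Among the compounds with values here, compound 2, at 1630 nM, holds the only numerical value so far, so it has no numerical neighbour against which to rank it.

The next compound to be read is compound 3 `CC(=O)C[Se]C(=O)c1ccc(Cl)cc1`, which keeps the rest of compound 2 and carries methyl in place of tert-butyl on a carbonyl carbon. Within the data shown here, no measured pair shows what such a change does, so the expectation rests on compound 2 at 1630 nM alone. A modest loss of potency in this assay is expected, with a result close to the scatter of the assay quite possible. The expected change is a 1.7-fold higher number from compound 2 to compound 3 (0.23 log units; within the scatter). For compound 3 the estimated value is 2800 nM, with an expected range of 800 nM to 10000 nM.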

Compound 3, half-maximal inhibitory concentration: 5480 nM
The estimate for compound 3 lay 2.0-fold (0.29 log units) below the measured number, and the stated range covers the measured number.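

Within the data shown here, replacing tert-butyl with methyl on a carbonyl carbon gives a 3.4-fold higher number from compound 2 to compound 3 (0.53 log units; beyond the scatter) in this assay, the only step that can be read so far, which shows that this position responds to the group it carries. Compound 3 still gives a numerical value of 5480 nM, so in this pair a measurable read-out does not depend on keeping the tert-butyl group. The data shown offer nothing that accounts for the size or direction of this step.

On these data alone, with only tert-butyl and methyl read at this position, it remains open whether the number changes steadily across intermediate groups such as ethyl or isopropyl, or whether a phenyl ring or an amine in the same place would fit the same direction. Also open, as far as these compounds go, is the contribution of the chlorine shared by compound 2 and compound 3, which a comparison with fluorine or methoxy in its place would address while the rest of the structure stays the same.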